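A few compounds are considered here, and "the series" means these few. Any claim that something is new, unique, unknown or untested is made for them only; others in the source may bear on it.

Measured so far:
compound 1 `O=C1NC(=S)S/C1=C\C=C\c1ccccc1`, 81%
compound 2 `COc1cccc(COc2ccccc2/C=C/C=C2\SC(=S)NC2=O)c1`, 82%
compound 3 `COc1ccccc1/C=C/C=C1\SC(=S)NC1=O`, 69%

In a functional assay on DLD-1 cells (Homo sapiens), read by microscopy and crystal violet staining, with a stated time of 20 h, tested at 10 ug/mL (a higher number here means more inhibition at the concentration tested (going by the name of the read-out), a lower number less inhibition), compound 1 stands second of the three; compound 2 lies within the scatter of it, and compound 3 sits beyond the scatter below it.

Compound 4 `O=C1NC(=S)S/C1=C\C=C\c1ccccc1OCc1ccccc1` differs from compound 1 by benzyloxy in place of hydrogen on an aromatic carbon. Going by the values given here, two measured steps bear on this. a number 12 percentage points lower from compound 1 to compound 3 (beyond the scatter) shows that a small group at this place lowers the read-out. a number 13 percentage points lower from compound 2 to compound 3 (beyond the scatter) shows that extending that place to the larger aryl-methoxy group brings the value back to the level of compound 1. Compound 4 carries a group of the latter kind, so no step beyond the scatter is expected; a number 1 percentage points lower from compound 1 to compound 4 (within the scatter) is the expectation. Compound 4 is thus estimated at 80%, range 68% to 90%.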

Compound 4, a percentage reported as inhibition, at one concentration (the size of the read-out at that concentration, not a potency): 65%
Beside the measured number, compound 4's estimate is 15 percentage points above it; measured number below the stated range.
By their numbers in this assay, from the lowest: compounds 4 and 3 (each within the scatter of the next); then compounds 1 and 2 (each within the scatter of the next).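

Benzyloxy in place of hydrogen on this aromatic carbon does not hold the level of the unsubstituted parent: a number 16 percentage points lower from compound 1 to compound 4 (beyond the scatter), while phenyl in place of hydrogen on the chain carbon gives no step beyond the scatter, a number 4 percentage points lower from compound 3 to compound 4 (within the scatter). The higher read-out of compound 2 therefore traces to the methoxy on its outer phenyl, a number 17 percentage points lower from compound 2 to compound 4 (beyond the scatter). In this assay, methoxy in place of hydrogen on an aromatic carbon depends on the core that carries it: the same change on two cores in this assay, a number 12 percentage points lower (beyond the scatter) from compound 1 to compound 3 and a number 17 percentage points higher (beyond the scatter) from compound 4 to compound 2, 29 percentage points apart, beyond the scatter of two such steps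

On these data alone, whether an amine or a carboxylic acid in place of that methoxy would keep the read-out at the level of compound 2 stays open. The single-concentration read-out also leaves potency open.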